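A few compounds are considered here, and "the series" means these few. Any claim that something is new, unique, unknown or untested is made for them only; others in the source may bear on it.

Measured so far, all in an ADME assay on HCT-116 cells (Homo sapiens) for antiproliferative activity (on this read-out higher numbers stand for weaker inhibition and lower numbers for stronger inhibition), only:
compound 1 (`COc1ccc(C(N)=O)cc1COc1ccc(Cl)cc1`): > 50000 nM (a limit of the assay)
compound 2 (`COc1ccc(C(N)=O)cc1/C=C/c1ccc(Cl)cc1`): 7100 nM as a number
compound 3 (`COc1ccc(C(N)=O)cc1/C=C\c1ccc(Cl)cc1`): 29000 nM as a number

Compound 2 with 7100 nM holds the lower of the two numbers in this assay and serves as the reference here. Compound 1 offers only a limit, so no step can be read from it. The nearest number lies at the end of a 4.1-fold higher number from compound 2 to compound 3 (0.61 log units; beyond the scatter) and this gap goes with the fact that compounds 2 and 3 differ only in the configuration as drawn rather than with any change of substituent.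

Compound 4 (`COc1ccc(C(N)=O)cc1/C=C/c1ccc(C(F)(F)F)cc1`) has not been measured. The change from compound 2 is trifluoromethyl in place of chloro on an aromatic carbon and it sits on an aromatic carbon of a six-membered aromatic ring of carbon only, para to a large group.

Among the measured compounds shown here, no measured step alters this substituent. For the measured compounds named here, the only sized step, a 4.1-fold higher number from compound 2 to compound 3 (0.61 log units; beyond the scatter) and nothing else, concerns configuration and bears on this change only indirectly, as a measure of how far a single change has moved the number. No shift beyond the scatter is therefore expected, in either direction. The expected step is a 1.3-fold higher number from compound 2 to compound 4 (0.10 log units; within the scatter) and the range around it stays wide. For compound 4 the estimated value is 9000 nM (expected range 3000 nM to 30000 nM).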

Compound 4, half-maximal inhibitory concentration: 35000 nM
Beside the measured number, compound 4's estimate is 3.9-fold (0.59 log units) below it; the measured number lies above the stated range.
By their numbers in this assay, from the lowest: compound 2; then compounds 3 and 4 (each within the scatter of the next). At a limit, above all of these: compound 1.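

In this assay, among the compounds shown here, the only sized step at this position, on an aromatic carbon para to a large group, is a 4.9-fold higher number from compound 2 to compound 4 (0.69 log units; beyond the scatter), so the substituent here does move the number beyond the scatter. The earlier sized step, a 4.1-fold higher number from compound 2 to compound 3 (0.61 log units; beyond the scatter), concerned configuration alone; this one shows that the series also responds to a change of substituent with the E double bond kept, and that of the two groups shown here, chloro carries the lower number. Nothing in the data at hand accounts for this step.

With only chloro and trifluoromethyl shown at this position, it remains open whether the number follows the heavy-atom count of the group or some other feature of it, and a fluoro, a methoxy group, an amine or a plain ring hydrogen at the same place would help to separate these readings. On these data alone, it also remains open whether trifluoromethyl in place of chloro gives a step of similar direction and size on the Z double bond of compound 3.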